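A few compounds are considered here, and "the series" means these few. Any claim that something is new, unique, unknown or untested is made for them only; others in the source may bear on it.

Measured so far:
compound 1 `Nc1ccccc1NC(=O)c1ccc(CSC(=S)N2CCN(C3CCCCC3)CC2)cc1`: 75.3%
compound 2 `Nc1ccccc1NC(=O)c1ccc(CSC(=S)N2CCN(c3cnccn3)CC2)cc1`: 80.5%

Both numbers come from a functional assay on MGC-803 cells (Homo sapiens) for antiproliferative activity, read by CCK-8 assay, with a stated time of 72 h, tested at 8 uM; a lower number here means a weaker effect, a higher number a stronger effect of the compound at the concentration tested. Within the data shown here, compound 2 stands level with compound 1: the one step measured so far, a number 5.2 percentage points higher from compound 1 to compound 2 (within the scatter), lies within the scatter, so the two readings cannot be told apart on the data at hand. That step swaps the group on the ring nitrogen of the shared core, pyrazin-2-yl in place of cyclohexyl, and it leaves this assay essentially unchanged.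

Compound 3 `Nc1ccccc1NC(=O)c1ccc(CSC(=S)N2CCN(Cc3cccnc3)CC2)cc1` is the next member, differing from compound 2 in one place: (pyridin-3-yl)methyl in place of pyrazin-2-yl on an amine nitrogen in a ring. Among the measured compounds shown here, the only measured step that bears on it is the one at the same ring nitrogen, a number 5.2 percentage points higher from compound 1 to compound 2 (within the scatter), which was within the scatter. The change from compound 2 to compound 3 is a different swap at that position, so it is not covered directly, but there is nothing in the two numbers that points to a shift beyond the scatter in this assay in either direction.

Compound 3 is therefore expected to give 77%, with a range from 64% to 88%. This estimate means a step of a number 3.5 percentage points lower from compound 2 to compound 3 (within the scatter), within the scatter.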

Compound 3, a percentage reported as inhibition, at one concentration (the size of the read-out at that concentration, not a potency): 64.6%
Beside the measured number, compound 3's estimate is 12.4 percentage points above it, within the range that was stated.
By their numbers in this assay, from the lowest: compound 3; then compounds 1 and 2 (each within the scatter of the next).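

In this assay the ring nitrogen of the shared core now shows a response to the group it carries: a number 15.9 percentage points lower from compound 2 to compound 3 (beyond the scatter), and a number 10.7 percentage points lower from compound 1 to compound 3 (beyond the scatter), both modest, whereas the earlier swap, a number 5.2 percentage points higher from compound 1 to compound 2 (within the scatter), could not be told from noise. An aromatic ring on this nitrogen does not on its own fix the level: compound 2 and compound 3 both carry a six-membered aromatic ring yet part beyond the scatter, while compound 2 and compound 1, the latter with cyclohexyl, stay within it. Nothing at hand gives a measured reason for the lower reading of compound 3.

The three compounds cannot separate the one-carbon link in (pyridin-3-yl)methyl from the change in ring nitrogens, as the two differ together in the step from pyrazin-2-yl. As far as these compounds go, a plain benzyl group or a pyridin-3-yl group attached directly to the ring nitrogen would pull these two apart, and whether either reads nearer compound 3 or nearer compound 2 remains open.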